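Ring-nitrogen substituent series: from compound 3 to compound 4

The compounds below may be only part of what the source reports. "The series", "measured", "known", "first", "only" and "open" are said of these compounds alone.

Compound 3 `CCCCNc1nc(N)nc2c1CN(S(C)(=O)=O)CC2` carries a methylsulfonyl group on the ring nitrogen of the shared core. Among the measured compounds shown here, in an assay on HEK293 cells for agonist activity at Toll-like receptor 8 (Homo sapiens), read by a luciferase reporter, with a stated time of 6 h (on this read-out higher numbers stand for an effect only at larger amounts of compound and lower numbers for an effect already at smaller amounts), compound 3 gives 9.9 uM, the highest of the three numbers measured so far. Compound 1 `CCCCNc1nc(N)nc2c1CNCC2`, with hydrogen at that nitrogen, gives 7.2 uM in this assay, and the step of a 1.4-fold higher number from compound 1 to compound 3 (0.14 log units; within the scatter) stays within the scatter. Compound 2 `CCCCNc1nc(N)nc2c1CN(C(=O)c1ccccc1)CC2`, with benzoyl at the nitrogen, gives 1.4 uM; the steps of a 5.1-fold lower number from compound 1 to compound 2 (0.71 log units; beyond the scatter) and a 7.1-fold higher number from compound 2 to compound 3 (0.85 log units; beyond the scatter) both lie beyond the scatter and set compound 2 apart from the other two.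

Compound 4 `CCCCNc1nc(N)nc2c1CN(Cc1ccccc1Cl)CC2` is reached by the change (2-chlorobenzyl in place of methylsulfonyl on an amine nitrogen in a ring). For the measured compounds named here, two measured steps bear on it: hydrogen to benzoyl gave a 5.1-fold lower number from compound 1 to compound 2 (0.71 log units; beyond the scatter), and benzoyl to methylsulfonyl gave a 7.1-fold higher number from compound 2 to compound 3 (0.85 log units; beyond the scatter). In both, the compound bearing an aromatic ring on this nitrogen had the lower number and methylsulfonyl stood at the high end. Because of a 7.1-fold higher number from compound 2 to compound 3 (0.85 log units; beyond the scatter), a lower number is expected for compound 4 in this assay, with the step estimated as a 5.0-fold lower number from compound 3 to compound 4 (0.69 log units; beyond the scatter). The benzyl attachment is not the benzoyl of compound 2, so the range is kept wide. Compound 4 is expected to give about 2 uM, between 0.5 uM and 8 uM.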

Compound 4, minimum effective concentration: 0.05 uM
For compound 4 the middle estimate is 40-fold (1.60 log units) above the measured one, outside the stated range (below it).
By their numbers in this assay, from the lowest: compound 4; then compound 2; then compounds 1 and 3 (each within the scatter of the next).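

Working notes on the result: in this assay this ring nitrogen carries far more of the effect than the first three compounds showed, since 2-chlorobenzyl in place of methylsulfonyl gives a 200-fold lower number from compound 3 to compound 4 (2.30 log units; beyond the scatter) and 2-chlorobenzyl in place of hydrogen gives a 140-fold lower number from compound 1 to compound 4 (2.16 log units; beyond the scatter). An aromatic ring on this nitrogen is not enough to account for the low number, as compound 2 also carries one and the change from benzoyl to 2-chlorobenzyl still gives a 28-fold lower number from compound 2 to compound 4 (1.45 log units; beyond the scatter), a step in which loss of the carbonyl and arrival of the chlorine stand together and cannot be told apart. No measurement at hand bears on why this step is so large.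

From the compounds shown here alone, what remains open is whether the chlorine or the benzyl attachment carries the step, which a plain benzyl group or a 2-fluorobenzyl group on the same nitrogen would help to separate. Also open, going by these compounds, is how a longer link to the aromatic ring, as in a phenethyl group, or a simple alkyl chain such as butyl on this nitrogen would stand against compound 4 in this assay.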